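From Fluoro to Ethoxy in a Weakly Active Series

A few compounds are considered here, and "the series" means these few. Any claim that something is new, unique, unknown or untested is made for them only; others in the source may bear on it.

In a functional assay on MDA-MB-231 cells (Homo sapiens) for antiproliferative activity, read by sulforhodamine B assay, with a stated time of 72 h (on this read-out lower numbers stand for stronger inhibition and higher numbers for weaker inhibition), compound 1 (`O=c1c(-c2csc3ccccc23)coc2ccccc12`) gives > 10000 nM, which is a limit of the assay and not a number. Compound 2 (`COc1c(OC(C)C)cc2oc(-n3cncn3)c(-c3csc4ccccc34)c(=O)c2c1OC(C)C`) gives > 10000 nM, which is also a limit. Within the data shown here, compound 3 (`O=C(/C=C/c1csc2ccccc12)c1cc(F)ccc1O`) gives 8400 nM, the only true number so far. Compound 4 (`CCOc1ccc(O)c(C(=O)/C=C/c2csc3ccccc23)c1`) differs from compound 3 in one place, with ethoxy in place of fluoro on an aromatic carbon, para to a hydroxy group: ethoxy in place of fluoro on an aromatic carbon. Among the measured compounds shown here, no measured pair shows what this swap does, so no change beyond the usual scatter is expected, in either direction. The expected step is a 1.3-fold lower number from compound 3 to compound 4 (0.11 log units; within the scatter). For compound 4, the estimate is 6500 nM, with an expected range of 2000 nM to 15000 nM.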

Compound 4, half-maximal inhibitory concentration: 6700 nM
The estimate for compound 4 lay 1.0-fold (0.01 log units) below the measured number, within the range that was stated.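

Ethoxy in place of fluoro, on the aromatic carbon para to a hydroxy group, is the first change in this set that can be read as a step: in this assay it gives a 1.3-fold lower number from compound 3 to compound 4 (0.10 log units; within the scatter). This position therefore takes 3 heavy atoms instead of 1, plus a hydrogen-bond acceptor, with no change beyond the scatter. Compound 1 and compound 2 each give a limit of the assay and not a number: the limit of > 10000 nM in this assay, at which 2 of the 4 values shown sit.

From the compounds shown here alone, whether an amine, a carboxylic acid or a longer chain at this position would move the number beyond the scatter stays open. So does what the hydroxy group itself contributes.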